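Amide variation at the carbonyl on the shared core

The compounds below may be only part of what the source reports. "The series", "measured", "known", "first", "only" and "open" are said of these compounds alone.

Measured compounds
compound 1, `CN(C(=O)CCc1ccccc1)c1ccc2[nH]c(-c3n[nH]c4ccccc34)cc2n1`: 18100 nM
compound 2, `CN(C(=O)c1ccc([N+](=O)[O-])cc1)c1ccc2[nH]c(-c3n[nH]c4ccccc34)cc2n1`: 34500 nM

Both compounds were read in a functional assay on A549 cells (Homo sapiens) for antiproliferative activity, read by MTT assay, with a stated time of 72 h; a lower number here means a stronger inhibitor, a higher number a weaker inhibitor. Compound 2 stands at the upper end of the pair, but only by a 1.9-fold higher number from compound 1 to compound 2 (0.28 log units; within the scatter), so the two numbers are not separable on the data shown.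

Compound 3, `CN(C(=O)Nc1ccccc1)c1ccc2[nH]c(-c3n[nH]c4ccccc34)cc2n1`, keeps the shared core and the methylated amide-type nitrogen; the change is anilino in place of 4-nitrophenyl on a carbonyl carbon, turning the amide into a urea.

Going by the values given here, only one measured step bears on this position: the exchange of the group on the carbonyl carbon between compound 1 and compound 2 gave a 1.9-fold higher number from compound 1 to compound 2 (0.28 log units; within the scatter). That single step, within the scatter, is the whole precedent; there is no measured urea in the set, so the anilino group has no direct comparator. The expectation is therefore a step of a 1.4-fold lower number from compound 2 to compound 3 (0.14 log units; within the scatter), that is, none beyond the scatter in this assay. Compound 3 is estimated at 25000 nM, with a range from 8000 nM to 80000 nM.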

Compound 3, half-maximal inhibitory concentration: 1430 nM
Estimate against measurement, compound 3: 17-fold (1.24 log units) above; the whole stated range lies above it.
By their numbers in this assay, from the lowest: compound 3; then compounds 1 and 2 (each within the scatter of the next).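

In this assay the group on the carbonyl carbon proves able to move the number: anilino in place of 4-nitrophenyl gives (a 24-fold lower number from compound 2 to compound 3 (1.38 log units; beyond the scatter)), and anilino in place of phenethyl gives (a 13-fold lower number from compound 1 to compound 3 (1.10 log units; beyond the scatter)). The earlier exchange of phenethyl and 4-nitrophenyl stayed within the scatter, so the position looked flat between these two amides; the two new steps lie beyond the scatter and run the same way, which sets the urea compound 3 apart from both. The change also brings in a hydrogen-bond donor in place of a group with none, but nothing available ties the step to that difference or to any other feature of the anilino group.

From the compounds shown here alone, it remains open whether the step belongs to the urea linkage as such or to the anilino ring, and a benzylamino, cyclohexylamino or 4-nitroanilino group on the same carbonyl carbon would separate those readings. The compounds shown also leave open whether the methyl on the amide-type nitrogen contributes to the step, a question that the analogue carrying a hydrogen there would address.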